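The compounds below may be only part of what the source reports. "The series", "measured", "known", "first", "only" and "open" are said of these compounds alone.

In an ADME assay on MRC5 cells (Homo sapiens) for cytotoxicity, read by MTT assay, with a stated time of 72 h (a higher number here means a weaker inhibitor, a lower number a stronger inhibitor), compound 2 (`CSCC[C@H](NC1=CC(=O)C=C(C[C@]2(C)[C@@H](C)CC[C@]3(C)C(C)=CCC[C@@H]23)C1=O)C(=O)O`) gives > 200000 nM as a limit, not a number. Compound 1 (`CC(C)(C)C1=CC(=O)C=C(NCC(=O)O)C1=O`) gives > 200000 nM as a limit too. Compound 3 (`CC(C)[C@@H](NC1=CC(=O)C=C(C(C)(C)C)C1=O)C(=O)O`) gives > 200000 nM as a limit as well. Compound 4 (`CC1=CCC[C@H]2[C@](C)(CC3=CC(=O)C=C(N[C@@H](C)C(=O)O)C3=O)[C@@H](C)CC[C@]12C`) departs from compound 2 in one place, counted as hydrogen in place of (methylsulfanyl)methyl on a saturated chain carbon, two bonds along the chain from an amine nitrogen and a carbonyl carbon and amounting to hydrogen in place of (methylsulfanyl)methyl on a saturated chain carbon, two bonds along the chain from an amine nitrogen and a carbonyl carbon. Going by the values given here, the only measured step is a step that the two limits leave unreadable from compound 1 to compound 3 and it offers no size to carry over. Compound 2 shares the limit of > 200000 nM in this assay, at which 3 of the 3 values shown sit, with compound 1 and compound 3, so no step beyond the scatter is expected in this assay and no direction can be named. The expected move is a number no higher from compound 2 to compound 4 (the limit leaves the size open) by this estimate. For compound 4 the estimated value is 200000 nM with an expected range from 80000 nM to 400000 nM as its ends.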

Compound 4, half-maximal inhibitory concentration: 157000 nM
Beside the measured number, compound 4's estimate is 1.3-fold (0.11 log units) above it, and the stated range covers the measured number.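

In this assay compound 4 gives 157000 nM as the first actual number. From the compounds shown here alone, putting hydrogen in place of (methylsulfanyl)methyl at this chain carbon is read as an at least 1.2-fold lower number from compound 2 to compound 4 (0.10 log units; that floor lies within the scatter) and so the change cannot yet be told from scatter, while its true size stays open. Compound 2 itself remains a limit, as do most of the values shown: the limit of > 200000 nM in this assay, at which 3 of the 4 values shown sit.

Still open, going by these compounds, is how a benzyl group or a hydroxymethyl group on this chain carbon would read against compound 4. Whether any group there moves the number beyond the scatter is also unknown.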